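Two Chlorines on the Benzoyl Ring: Expected Cytotoxicity

This account rests on a few compounds, and the source may have more. Where it says the series, first, only, none or still open, it means among the compounds named here.

Measured so far in an ADME assay on Karpas-1106P cells (Homo sapiens) for cytotoxicity; a higher number here means that more compound is needed for the effect, a lower number that less compound is needed:
compound 1 `Cc1ccc(S(=O)(=O)N[C@@H](CC(=O)NC(C)(C)C)C(=O)NCCNS(=O)(=O)c2ccccc2)cc1`: > 11100 nM
compound 2 `Cc1ccc(S(=O)(=O)N[C@@H](CC(=O)NC(C)(C)C)C(=O)NCCNC(=O)c2ccccc2)cc1`: > 11100 nM

Both measured compounds share one core and differ only at the amine nitrogen, where compound 2 carries a benzoyl in place of the phenylsulfonyl of compound 1. For compound 1 the value > 11100 nM is a limit of this assay, not a number. For compound 2 the value > 11100 nM is likewise a limit of this assay. The step that the two limits leave unreadable from compound 1 to compound 2 therefore cannot be read, since (the limit of > 11100 nM in this assay, at which 2 of the 2 values shown sit).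

Compound 3 `Cc1ccc(S(=O)(=O)N[C@@H](CC(=O)NC(C)(C)C)C(=O)NCCNC(=O)c2cc(Cl)ccc2Cl)cc1` is not yet measured. It differs from compound 2 in one place: 2,5-dichlorophenyl in place of phenyl on a carbonyl carbon. For the measured compounds named here, no measured step involves a change on this carbonyl carbon, so nothing in the two values shown can be used to predict a direction for a step that the limit leaves unreadable from compound 2 to compound 3 beyond the scatter, and the step is expected to stay within it. Given that both values known so far are limits, compound 3 is expected to return a limit as well; its estimate is 15000 nM, with a range from 5000 nM to 45000 nM.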

Compound 3, half-maximal effective concentration: > 11100 nM
Compound 3: no number, only a limit; the forecaster's own chance of this, stated with the estimate: 80%; the middle value is on the limit's open side.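

Compound 3 returns only a limit in this assay, like compound 1 and compound 2, so no step among the three can be read: the limit of > 11100 nM in this assay, at which 3 of the 3 values shown sit.

Left open is how much of any of these compounds is needed for the effect in this assay and whether swapping phenylsulfonyl, benzoyl or (2,5-dichlorophenyl)carbonyl changes that amount at all.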